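Capping a hydroxy group on a dichlorophenyl compound

The compounds below may be only part of what the source reports. "The series", "measured", "known", "first", "only" and "open" are said of these compounds alone.

Measured in a functional assay on HL-60 cells (Homo sapiens) for cytotoxicity, read by WST assay, with a stated time of 48 h; on this read-out higher numbers stand for an effect only at larger amounts of compound and lower numbers for an effect already at smaller amounts:
- Compound 1 `COc1cccc(C[C@H]2COC[C@@H]2Cc2ccc(Cl)c(Cl)c2)c1`: 73000 nM
- Compound 2 `COc1cc(C[C@H]2COC[C@@H]2Cc2ccc(Cl)c(Cl)c2)ccc1O`: 21000 nM
- Compound 3 `COc1ccc(C[C@H]2COC[C@@H]2Cc2ccc(Cl)c(Cl)c2)cc1O`: 33000 nM

Compound 3 lies within the usual scatter of compound 2, so these two cannot be told apart. Its number is clearly lower than that of compound 1, and the gap goes beyond the scatter.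

The next compound is compound 4 `COc1ccc(C[C@H]2COC[C@@H]2Cc2ccc(Cl)c(Cl)c2)cc1OC`. The change from compound 3 is methyl in place of hydrogen on an oxygen on an aromatic ring, so hydroxy becomes methoxy. Compound 4 therefore carries no hydroxy, just like compound 1.

Among the compounds with values here, only one measured step bears on this. Adding a hydroxy gave a 3.5-fold lower number from compound 1 to compound 2 (0.54 log units; beyond the scatter), a modest change beyond the scatter. That step is not the same change, since there the hydroxy replaced a hydrogen on an aromatic carbon, so it offers only a rough guide. Even so, it suggests that losing the hydroxy could move the number partway back towards compound 1 at 73000 nM.

The expected change is small and upward, at the edge of the scatter: a 1.8-fold higher number from compound 3 to compound 4 (0.26 log units; within the scatter). The estimate for compound 4 is 60000 nM, with an expected range of 28000 nM to 130000 nM.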

Compound 4, half-maximal effective concentration: 16000 nM
Compound 4: the middle estimate sits 3.8-fold (0.57 log units) above what was measured, and the stated range ends above it.
By their numbers in this assay, from the lowest: compounds 4, 2 and 3 (each within the scatter of the next, the first and the last beyond it); then compound 1.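

Methyl in place of hydrogen on this oxygen on an aromatic ring gives, in this assay, a 2.1-fold lower number from compound 3 to compound 4 (0.31 log units; beyond the scatter) and so shows that the hydroxy hydrogen is not needed to keep the effect of compound 3 in this series. Methoxy also moves the number in the same direction as the hydroxy did earlier: the comparison with the parent gives a 4.6-fold lower number from compound 1 to compound 4 (0.66 log units; beyond the scatter) and the comparison of the two substituted compounds gives a 1.3-fold lower number from compound 2 to compound 4 (0.12 log units; within the scatter) and leaves them impossible to tell apart, so at that aromatic carbon a capped oxygen serves as well as a free hydroxy. Nothing available here accounts for these shifts, and the reason for them stays unknown.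

Going by these compounds, it remains open how a longer chain on this oxygen, such as ethoxy or butoxy, would read, and whether an amine or a carboxylic acid in place of the methoxy would keep the number where it is. On these data alone, all four compounds also share one core, so whether this step would carry over to any other core is unknown.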